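The compounds below may be only part of what the source reports. "The series", "measured", "known", "first", "only" and "open" are said of these compounds alone.

Measured so far in a physicochemical assay for solubility, read by HPLC, in phosphate buffer, with a stated time of 16 h, at pH 6.8; a lower number here means a less soluble compound, a higher number a more soluble compound:
- Compound 1 `C[C@H](NC(=O)Cn1nnc2ccccc2c1=O)c1ccc(Cl)cc1`: 1900 nM
- Compound 2 `Cc1ccc([C@H](C)NC(=O)Cn2nnc3ccccc3c2=O)c(C)c1`: 2700 nM
- Compound 3 `Cc1ccc([C@H](C)NC(=O)Cn2nnc3ccccc3c2=O)c(F)c1`: 4500 nM

Compound 1 sits at the low end of these numbers, level with compound 2 within the scatter and clearly under compound 3. Compound 4 `C[C@H](NC(=O)Cn1nnc2ccccc2c1=O)c1ccc(OC(F)F)cc1` has not been measured. It carries difluoromethoxy in place of chloro on an aromatic carbon.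

Two measured steps replace the 4-chlorophenyl group of compound 1, though neither brings in difluoromethoxy: a 1.4-fold higher number from compound 1 to compound 2 (0.15 log units; within the scatter), and a 2.4-fold higher number from compound 1 to compound 3 (0.37 log units; beyond the scatter). Both point upward and both are small, so a slight rise in this assay is expected, probably none beyond the scatter.

The estimated step is a 1.3-fold higher number from compound 1 to compound 4 (0.12 log units; within the scatter).

For compound 4 the expected value is 2500 nM, with an estimated range of 1000 nM to 6500 nM.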

Compound 4, solubility: 2400 nM
The estimate for compound 4 lay 1.0-fold (0.02 log units) above the measured number, and the stated range covers the measured number.
By their numbers in this assay, from the lowest: compounds 1, 4, 2 and 3 (each within the scatter of the next, the first and the last beyond it).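

In this assay, replacing chloro with difluoromethoxy on this aromatic carbon, para to a large group, gives a small step (a 1.3-fold higher number from compound 1 to compound 4 (0.10 log units; within the scatter)). Unlike the changes in compound 2 and compound 3, this one alters a single group on the ring, and 4 heavy atoms in place of 1 leave the number within the scatter. No measurement here explains this result.

On these data alone, whether an amine or a carboxylic acid at this position would also stay close to compound 1 remains open.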